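Swapping the Ring at the End of the Chain

This account rests on a few compounds, and the source may have more. Where it says the series, first, only, none or still open, it means among the compounds named here.

Compound 1, `Clc1cccc(Nc2ncnc3ccc(NCc4cccnc4)cc23)c1`, gives 2670 nM in a functional assay on A549 cells (Homo sapiens) for antiproliferative activity, read by MTT assay, with a stated time of 48 h; a lower number here means a stronger inhibitor, a higher number a weaker inhibitor.
Compound 2, `Cc1cccc(CNc2ccc3ncnc(Nc4cccc(Cl)c4)c3c2)n1`, gives 1060 nM in this assay.
Compound 3, `O=C(/C=C/c1cccnc1)Nc1ccc2ncnc(Nc3cccc(Cl)c3)c2c1`, gives 4320 nM in this assay.

Compound 3 has the highest number of the three, though its gap to compound 1 lies within the scatter; only compound 2 is clearly lower. Compound 4, `O=C(/C=C/c1cccs1)Nc1ccc2ncnc(Nc3cccc(Cl)c3)c2c1`, differs from compound 3 by one change: thiophen-2-yl in place of pyridin-3-yl on a double-bonded chain carbon bound to a double-bonded chain carbon. Going by the values given here, no measured step concerns this kind of swap. Among the compounds with values here, the only measured step, a 2.5-fold lower number from compound 1 to compound 2 (0.40 log units; beyond the scatter), changes a ring on a saturated chain carbon, a different place and a different pair of rings, so it offers no guide. With nothing pointing either way, compound 4 is expected to sit near compound 3, with a step of a 1.2-fold lower number from compound 3 to compound 4 (0.09 log units; within the scatter) that is not expected to exceed the scatter. Compound 4 is therefore estimated at 3500 nM, in a range from 1200 nM to 10000 nM.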

Compound 4, half-maximal inhibitory concentration: 9310 nM
Beside the measured number, compound 4's estimate is 2.7-fold (0.42 log units) below it; measured number inside the range.
By their numbers in this assay, from the lowest: compound 2; then compounds 1 and 3 (each within the scatter of the next); then compound 4.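

In this assay the ring at this place does count: thiophen-2-yl in place of pyridin-3-yl gives a 2.2-fold higher number from compound 3 to compound 4 (0.33 log units; beyond the scatter) and so makes the compound a weaker inhibitor. Larger gaps come with an 8.8-fold higher number from compound 2 to compound 4 (0.94 log units; beyond the scatter) and with a 3.5-fold higher number from compound 1 to compound 4 (0.54 log units; beyond the scatter) but in those steps the whole group on the nitrogen changes, so the effects of ring and chain cannot be told apart. No measured evidence explains these differences. As far as these compounds go, it remains open how a phenyl ring or a dimethylamine at the chain end would fare, and whether thiophen-2-yl on the saturated chain carbon would give a similar shift.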